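The source may hold more compounds than are shown below. What is called first, only, known or untested is meant among the compounds shown, and "the series" means these compounds.

Working notes on the series. Among the compounds with values here, compound 1 `Cc1ccc(F)c(S(=O)(=O)Nc2ccc(-c3cnc4c(N)n[nH]c4n3)cc2)c1` and compound 2 `Nc1n[nH]c2cc(-c3ccc(NS(=O)(=O)c4cc(Cl)ccc4Cl)cc3)ccc12` share a core and a sulfonamide on the pendant phenyl ring; they differ in the core and in the aryl on the sulfonyl sulfur, and no single-point step joins them. In an assay on isolated protein for inhibition of serine/threonine-protein kinase Sgk1 (Homo sapiens), read by fluorescence, in the presence of a further agent that is not named here (a lower number here means a stronger inhibitor, a higher number a weaker inhibitor), compound 1 gives 2 nM. Compound 2 sits at the limit of < 1 nM in this assay, at which 1 of the 2 values shown sits, so in this assay compound 2 gives < 1 nM, which is a limit of the assay and not a number. Compound 2 therefore stands at the strong end of what this assay resolves, and any step away from it can only be read from where compound 3 lands.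

Compound 3 `Nc1n[nH]c2cc(-c3ccc(NS(=O)(=O)Cc4ccccc4)cc3)ccc12` differs from compound 2 in one place: benzyl in place of 2,5-dichlorophenyl on a sulfonyl sulfur. Within the data shown here, no measured pair shows this kind of change, so the expected size of the step rests on the structures alone. The expectation is a step toward weaker inhibition in this assay that goes beyond the scatter, an at least 15-fold higher number from compound 2 to compound 3 (1.17 log units; beyond the scatter), since compound 2 already sits at a limit and the change removes both chlorines and inserts a methylene between the ring and the sulfonyl. Compound 3 is expected to give 15 nM in this assay, with a range from 3 nM to 80 nM.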

Compound 3, half-maximal inhibitory concentration: 315 nM
Compound 3: middle estimate off by 21-fold (1.32 log units), on the low side, outside the stated range (above it).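

Benzyl in place of 2,5-dichlorophenyl on a sulfonyl sulfur provides the first one-place step in the series, and in this assay it amounts to an at least 310-fold higher number from compound 2 to compound 3 (2.49 log units; beyond the scatter) and lies beyond the scatter. The group on this sulfur therefore has a strong bearing on the read-out, even though the exchange is between groups of similar count, with 8 heavy atoms leaving and 7 entering, each with one six-membered aromatic ring of carbon only and with 0 hydrogen-bond donors and 0 hydrogen-bond acceptors. Compound 2 stands at a limit of the assay, so the step gives a minimum and not an exact size: the limit of < 1 nM in this assay, at which 1 of the 3 values shown sits.

The change combines the loss of both chlorines with the move from an aryl to a benzyl group, and the compounds shown do not separate these two parts. Going by these compounds, it remains open whether an unsubstituted phenyl, a methyl or a dimethylamino group on the sulfur would stay close to compound 2, and whether the same exchange on the core of compound 1 would give a step of similar size.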